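Swapping Cyclohexyl for 4-Fluorophenyl on the Imine Nitrogen

The source may report more compounds than this note shows. Statements on the series, on what has been measured and on what is new or still open speak of the compounds shown alone.

compound 1 `CC(C)C1CC(=O)c2s/c(=N/c3ccccc3)oc2C1`: 1150 nM
compound 2 `CC(C)C1CC(=O)c2s/c(=N/C3CCCCC3)oc2C1`: 3530 nM

Among the compounds with values here, in a functional assay on HCT-15 cells (Homo sapiens) for antiproliferative activity, read by sulforhodamine B assay (a lower number here means a stronger inhibitor of growth, a higher number a weaker inhibitor of growth), compound 2 gives the higher of the two measured numbers; compound 1 is its only neighbour and sits at a lower number, a gap beyond the scatter. Compound 3 `CC(C)C1CC(=O)c2s/c(=N/c3ccc(F)cc3)oc2C1` arises from compound 2 by this change: 4-fluorophenyl in place of cyclohexyl on a double-bonded nitrogen. Within the data shown here, the one step that bears on it is the move the other way, a 3.1-fold higher number from compound 1 to compound 2 (0.49 log units; beyond the scatter), which lowered activity when the aromatic ring was replaced by cyclohexyl. Returning to an aromatic ring, now carrying fluorine, is therefore expected to reverse that loss: an estimated 3.2-fold lower number from compound 2 to compound 3 (0.51 log units; beyond the scatter). Compound 3 is estimated at 1100 nM, with a likely range of 400 nM to 3000 nM.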

Compound 3, concentration for 50% growth inhibition: 2990 nM
The estimate for compound 3 lay 2.7-fold (0.43 log units) below the measured number; measured number inside the range.
By their numbers in this assay, from the lowest: compound 1; then compounds 3 and 2 (each within the scatter of the next).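

In this assay, an aromatic ring on the double-bonded nitrogen is not enough on its own to match compound 1: 4-fluorophenyl in place of cyclohexyl gives a 1.2-fold lower number from compound 2 to compound 3 (0.07 log units; within the scatter). Adding fluorine to the phenyl ring matters here, with a 2.6-fold higher number from compound 1 to compound 3 (0.41 log units; beyond the scatter), so compound 1 stands apart from both others. Nothing available explains this difference.

As far as these compounds go, it remains open whether this loss is specific to fluoro or would also appear with chloro or methoxy on the phenyl ring. From the compounds shown here alone, the effect of an amine on that ring is also open.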